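Working notes: expected stability of compound 4 against compound 1

The source may hold more compounds than are shown below. What is called first, only, known or untested is meant among the compounds shown, and "the series" means these compounds.

Measured so far in an ADME assay on microsomes from liver (Homo sapiens) for metabolic stability, with a stated time of 30 min; on this read-out higher numbers stand for a more stable compound and lower numbers for a less stable compound:
compound 1 `Cc1nc(N2CCC(N3CCOC3=O)CC2)nc2ccc(NC(=O)/C=C/c3ccc(OC(F)(F)F)cc3)cc12`: 85%
compound 3 `Cc1nc(N2CCC(N3CCCC3=O)CC2)nc2ccc(NC(=O)/C=C/c3ccc(Cl)cc3)cc12`: 50%
compound 2 `Cc1nc(N2CCC(O)(C3CC3)CC2)nc2ccc(NC(=O)COc3ccc(OC(F)(F)F)cc3)cc12`: "not determined" (no result reported)

Compound 1 holds the highest of the two numbers obtained in this assay. For the measured compounds named here, its nearest neighbour is compound 3, whose value lies well beyond the scatter below that of compound 1; compound 3 differs from compound 1 in more than one place, so the two values show only that compound 3 is less stable, not what either change contributes. For compound 2 no result was reported.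

Compound 4 `Cc1nc(N2CCC(N3CCN(C)C3=O)CC2)nc2ccc(NC(=O)/C=C/c3ccc(OC(F)(F)F)cc3)cc12` has not been measured. It differs from compound 1 in one place: 3-methyl-2-oxoimidazolidin-1-yl in place of 2-oxo-1,3-oxazolidin-3-yl on a saturated ring carbon. Going by the values given here, no pair of measured compounds differing only at this position is available, so the step cannot be read from the data.

With both groups being five-membered non-aromatic rings with two hetero atoms and no donor, and the change being exchange of one ring oxygen for a methylated nitrogen, a step within the scatter of this assay, or at most a small loss, is expected from compound 1 to compound 4, about a number 10 percentage points lower from compound 1 to compound 4 (within the scatter). Compound 4 is therefore estimated at 75% in this assay, with a range from 55% to 92%.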

Compound 4, percent of the compound remaining: 33%
Compound 4: middle estimate off by 42 percentage points, on the high side; measured number below the stated range.
By their numbers in this assay, from the lowest: compound 4; then compound 3; then compound 1.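

For the compounds shown here, this is the first single-place step at this position in this assay: exchanging the 2-oxo-1,3-oxazolidin-3-yl group for the 3-methyl-2-oxoimidazolidin-1-yl group gives a number 52 percentage points lower from compound 1 to compound 4 (beyond the scatter). The gap between compound 1 and compound 3 could not be assigned to any one place, whereas this step ties a large change in stability to this substituent alone, with the rest of compound 1 unchanged. Both groups are five-membered non-aromatic rings with 2 hetero atoms and no hydrogen-bond donors, so these shared counts do not make the two groups interchangeable here, and no measurement at hand bears on the reason for the step.

From the compounds shown here alone, it remains open whether the loss follows the ring nitrogen itself or the methyl group on it, a question that the unmethylated 2-oxoimidazolidin-1-yl ring would address at the same ring carbon. Also open, going by these compounds, is whether the exchange gives a step of similar size with other groups elsewhere in the molecule, such as a 4-chlorophenyl group in place of the 4-(trifluoromethoxy)phenyl group.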